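Replacing the 2-carbamoylpropyl group on the shared core

The source may report more compounds than this note shows. Statements on the series, on what has been measured and on what is new or still open speak of the compounds shown alone.

Among the compounds with values here, in a physicochemical assay for lipophilicity, read by HPLC, at pH 7.5 (on this read-out higher numbers stand for higher lipophilicity and lower numbers for lower lipophilicity), compound 2 (`CCOc1ccccc1-c1ccc(-c2nc3cnccc3c(C[C@H](C)C(N)=O)c2C#N)cc1`) gives 3 as the higher of the two numbers so far, and compound 1 (`CCOc1ccccc1-c1ccc(-c2nc3cnccc3c(N[C@H](CC)C(=O)NS(C)(=O)=O)c2C#N)cc1`) gives 2.2 as the lower. Compound 3 (`CCOc1ccccc1-c1ccc(-c2nc3cnccc3c(NC(CC)CNS(=O)(=O)C3CC3)c2C#N)cc1`) is still unmeasured and differs from compound 2 by a group of 12 heavy atoms (7 carbon, 2 nitrogen, 2 oxygen, 1 sulfur; one three-membered non-aromatic ring of carbon only) in place of a group of 6 heavy atoms (4 carbon, 1 nitrogen, 1 oxygen; no ring), on an aromatic carbon at a site ortho to a cyano group and opposite the ring nitrogen. Within the data shown here, only one measured step bears on this change, namely a number 0.80 log units higher from compound 1 to compound 2 (beyond the scatter) on passing from a larger sulfur-bearing group to the smaller 2-carbamoylpropyl group. That step is only a loose guide, since the group entering compound 3 carries a three-membered ring of carbon only and the group in compound 1 has no ring. The expected step is a number 0.40 log units higher from compound 2 to compound 3 (beyond the scatter) in this assay and thus small and upward. For compound 3 the expected value is 3.4 within a range from 2.8 to 4 in this estimate.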

Compound 3, distribution coefficient: 3.6
Compound 3: the middle estimate sits 0.20 log units below what was measured, and the stated range covers the measured number.
By their numbers in this assay, from the lowest: compound 1; then compound 2; then compound 3.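

In this assay, the group entering at this site, on an aromatic carbon opposite the ring nitrogen, gives a number 0.60 log units higher from compound 2 to compound 3 (beyond the scatter), so a larger group with more hydrogen-bond donors and acceptors than 2-carbamoylpropyl still raises the number here. With the attachment taken as a nitrogen on an aromatic ring, the change from a group with no ring to one carrying a three-membered ring of carbon only gives a number 1.40 log units higher from compound 1 to compound 3 (beyond the scatter), a large step that places compound 3 above both earlier compounds. Nothing measured here accounts for either step.

The compounds shown cannot separate the part played by the three-membered ring from that of the rest of the chain. As far as these compounds go, how an open-chain isopropyl on the sulfonyl group, an amine or a carboxylic acid would read at this site remains open.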